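A few compounds are considered here, and "the series" means these few. Any claim that something is new, unique, unknown or untested is made for them only; others in the source may bear on it.

Measured compounds:
- compound 1 `C[C@H](NC(=O)CN(c1nc(Cl)nc2[nH]cnc12)C1CC1)C(=O)OCc1ccccc1`: in a functional assay on the whole organism (Tail, strain ICR) with Mus musculus as the target, in the tail flick test, with a stated time of 150 min, at a dose of 25 umol/kg by the oral route (on this read-out lower numbers stand for a weaker effect and higher numbers for a stronger effect at the one dose given), compound 1 gives 23%
- compound 2 `CC[C@H](C)[C@H](NC(=O)CN(c1ncnc2c1ncn2C1CCCCO1)C1CC1)C(=O)OCc1ccccc1`: in this assay compound 2 gives 16.4%
- compound 3 `NC(=O)C[C@H](NC(=O)CN(c1nc(Cl)nc2[nH]cnc12)C1CC1)C(=O)O`: in this assay compound 3 gives 7.51%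

Compound 1 gives the highest of the three numbers in this assay. Compound 2 comes nearest; the gap between compound 1 and compound 2 is within the usual scatter, so the two cannot be ranked against each other. Compound 3 lies furthest from compound 1, and that gap is beyond the scatter; compound 3 also differs from compound 1 in more than one place. For the measured compounds named here, no pair of the measured compounds differs in a single place, so no measured step is available for the series.

Compound 4 `NCCCC[C@H](NC(=O)CN(c1nc(Cl)nc2[nH]cnc12)C1CC1)C(=O)OCc1ccccc1` is not yet measured. It is drawn from compound 1 by 3-aminopropyl in place of hydrogen on a saturated chain carbon, two bonds along the chain from an amide-type nitrogen and a carbonyl carbon; the rest of compound 1 remains unchanged. Nothing measured in this series speaks to a change at this place, so the expectation rests on compound 1 alone. The step from compound 1 to compound 4 in this assay is expected to be a number 5 percentage points lower from compound 1 to compound 4 (within the scatter), a small lowering that stays within the scatter. For compound 4 the expected value in this assay is estimated at 18%, with a range from 8% to 30%.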

Compound 4, a percentage reported as activity, at one dose (the size of the read-out at that dose, not a potency): 9.88%
Compound 4: middle estimate off by 8.1 percentage points, on the high side; the range from low to high includes it.
By their numbers in this assay, from the lowest: compounds 3, 4, 2 and 1 (each within the scatter of the next, the first and the last beyond it).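

In this assay, for the compounds shown here, the step at the saturated chain carbon, two bonds along the chain from an amide-type nitrogen and a carbonyl carbon, is the first single-place comparison: 3-aminopropyl in place of hydrogen gives a number 13.1 percentage points lower from compound 1 to compound 4 (beyond the scatter). Going by these compounds alone, this position is therefore not indifferent to substitution, since exchanging methyl for 4-aminobutyl while the rest of compound 1 stays unchanged moves the read-out beyond the scatter, something the earlier compounds, which differ in more than one place, could not show. No measurement of any property of these compounds bears on this step, and the change in the read-out remains unassigned.

A single step cannot separate the contribution of the chain from that of its terminal amine, so an unsubstituted butyl chain at the same carbon would be the direct comparison with compound 4. Also open, from the compounds shown here alone, is whether the lowering depends on the amine itself, which a carboxylic acid or a hydroxyl group at the end of the same chain would test.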